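The compounds below may be only part of what the source reports. "The series", "measured", "known", "first", "only" and "open" are said of these compounds alone.

Measured so far:
compound 1 `Oc1cccc(NCCCN2CCN(c3ccccc3)CC2)c1` — 10.1 nM in an assay on HEK293 cells for displacement of a labelled ligand from 5-hydroxytryptamine receptor 7 (Homo sapiens), read by scintillation counting, with a stated time of 30 min; a higher number here means a weaker inhibitor, a lower number a stronger inhibitor
compound 2 `Oc1cccc(N(CCCN2CCN(c3ccccc3)CC2)Cc2ccccc2)c1` — 92.5 nM

For the measured compounds named here, compound 2 has the higher of these two numbers; its nearest neighbour is compound 1, and the only measured step is a 9.2-fold higher number from compound 1 to compound 2 (0.96 log units; beyond the scatter). Compound 3 `O=S(=O)(c1ccccc1)N(CCCN1CCN(c2ccccc2)CC1)c1cccc(O)c1` is the next step from compound 2: phenylsulfonyl in place of benzyl on a nitrogen on an aromatic ring. Going by the values given here, the one measured step shows that adding a group on this nitrogen weakens binding, but no measured pair compares two different groups there, so the step from compound 2 is expected to be small and uncertain, a 1.4-fold higher number from compound 2 to compound 3 (0.15 log units; within the scatter). Compound 3 is therefore expected to give 130 nM, between 30 nM and 600 nM.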

Compound 3, inhibition constant: 12.1 nM
The estimate for compound 3 lay 11-fold (1.03 log units) above the measured number; measured number below the stated range.
By their numbers in this assay, from the lowest: compounds 1 and 3 (each within the scatter of the next); then compound 2.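

In this assay the kind of group on this nitrogen matters, not only whether one is present: phenylsulfonyl in place of benzyl gives a 7.6-fold lower number from compound 2 to compound 3 (0.88 log units; beyond the scatter). Phenylsulfonyl in place of hydrogen gives a 1.2-fold higher number from compound 1 to compound 3 (0.08 log units; within the scatter), so the loss seen with benzyl does not hold for every added group. Nothing measured here explains why these two groups differ. From the compounds shown here alone, whether acetyl or methylsulfonyl on this nitrogen would behave like phenylsulfonyl stays open. So does the effect of a chlorine or methoxy group on the phenyl ring of phenylsulfonyl.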